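From 2-methoxyphenyl to 1,3-thiazol-2-yl on the amide-type nitrogen

A few compounds are considered here, and "the series" means these few. Any claim that something is new, unique, unknown or untested is made for them only; others in the source may bear on it.

In a functional assay on MCF7 cells (Homo sapiens) for inhibition, read by MTT assay, with a stated time of 72 h (on this read-out lower numbers stand for stronger inhibition and higher numbers for weaker inhibition), compound 1 (`COc1cccc(NC(=O)C2CCN(C/C=C/c3ccccc3)CC2)c1`) gives 42700 nM as a measured number. Compound 2 (`COc1ccccc1NC(=O)C1CCN(C/C=C/c2ccccc2)CC1`) gives > 100000 nM and this is a limit of the assay, not a number. What is known of compound 2 is the limit of > 100000 nM in this assay, at which 1 of the 2 values shown sits, and no more.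

Compound 3 (`O=C(Nc1nccs1)C1CCN(C/C=C/c2ccccc2)CC1`) is still unmeasured. It carries 1,3-thiazol-2-yl in place of 2-methoxyphenyl on an amide-type nitrogen, counted as 1,3-thiazol-2-yl in place of 2-methoxyphenyl on an amide-type nitrogen with the rest of the structure unchanged.

Among the compounds with values here, one measured step bears on this change, at the same nitrogen: an at least 2.3-fold higher number from compound 1 to compound 2 (0.36 log units; beyond the scatter) as 2-methoxyphenyl replaces 3-methoxyphenyl. It shows that the group here can move the number, but it involves no 1,3-thiazol-2-yl. Within the data shown here, with compound 1 at 42700 nM as the only measured number, a small step towards a lower number in this assay is expected. A reading at the limit remains possible. The expected step is an at least 1.8-fold lower number from compound 2 to compound 3 (0.25 log units; that floor lies within the scatter) on this estimate. Compound 3 is estimated at 55000 nM with a range from 20000 nM to 100000 nM for now.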

Compound 3, half-maximal inhibitory concentration: 28600 nM
Compound 3: the middle estimate sits 1.9-fold (0.28 log units) above what was measured; the range from low to high includes it.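

In this assay, 1,3-thiazol-2-yl in place of 2-methoxyphenyl on the amide-type nitrogen gives an at least 3.4-fold lower number from compound 2 to compound 3 (0.54 log units; beyond the scatter) and so shows that a five-membered aromatic ring with 2 hetero atoms can stand at this place and still give a measured number. Set against the 3-methoxyphenyl group, the same 1,3-thiazol-2-yl group gives a 1.5-fold lower number from compound 1 to compound 3 (0.17 log units; within the scatter) and so does not separate from it, which leaves 2-methoxyphenyl as the one group of the three whose steps to both others lie beyond the scatter. The size of the step from the 2-methoxyphenyl group is only a floor, since compound 2 is held by a limit of the assay and not by a number: the limit of > 100000 nM in this assay, at which 1 of the 3 values shown sits.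

Open, on these data alone, is whether a pyridin-2-yl ring or a saturated cyclohexyl group on the amide-type nitrogen would read with compound 1 and compound 3 or with compound 2. Also open, as far as these compounds go, is whether a thiophen-2-yl group, with ring sulfur but no ring nitrogen, would give a reading like that of compound 3.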